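The compounds below may be only part of what the source reports. "The series", "measured", "known", "first", "only" and "open" are said of these compounds alone.

Values in a functional assay on HL-60 cells (Homo sapiens) for inhibition, read by MTT assay, with a stated time of 72 h (on this read-out lower numbers stand for stronger inhibition and higher numbers for weaker inhibition), follow
Compound 1 `Cc1nc(-c2ccccc2)c(C(=O)N2CCN(c3cccc(Cl)c3Cl)CC2)o1` gives 133 nM
Compound 2 `Cc1ccc(C)c(N2CCN(C(=O)c3oc(C)nc3-c3ccccc3)CC2)c1` gives 31.3 nM
Compound 3 `Cc1ccc(N2CCN(C(=O)c3oc(C)nc3-c3ccccc3)CC2)cc1` gives > 1000 nM

For compound 3, the entry > 1000 nM is a limit of the assay and not a number. It places compound 3 as the weakest of the three, with an at least 31-fold higher number from compound 2 to compound 3 (1.50 log units; beyond the scatter) and an at least 7.5-fold higher number from compound 1 to compound 3 (0.87 log units; beyond the scatter).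

Compound 4 `Cc1nc(-c2ccccc2)c(C(=O)N2CCN(c3ccc(C(F)(F)F)cc3)CC2)o1` differs from compound 3 in one group, trifluoromethyl in place of methyl on an aromatic carbon. Among the compounds with values here, no measured step makes this exchange. The two steps above, and a 4.2-fold lower number from compound 1 to compound 2 (0.63 log units; beyond the scatter), all alter the substitution pattern, whereas here the group stays para to a large group. No step beyond the scatter is therefore expected in this assay, though the limit on compound 3 keeps this loose. The estimated change is a step that the limit leaves unreadable from compound 3 to compound 4. For compound 4 the expected value is 1500 nM, within 500 nM to 5000 nM.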

Compound 4, half-maximal inhibitory concentration: > 1000 nM
Compound 4 gave a limit, no number; the forecaster's own chance of this, stated with the estimate: 65%; the middle value does not contradict the limit.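

Swapping methyl for trifluoromethyl does not lift this position out of the weak range: in this assay compound 4 gives > 1000 nM, which is a limit and not a number. The step between compound 3 and compound 4 cannot be read because both values are limits: the limit of > 1000 nM in this assay, at which 2 of the 4 values shown sit. Compound 4 stands clearly apart from the two compounds with numbers, with an at least 31-fold higher number from compound 2 to compound 4 (1.50 log units; beyond the scatter) and an at least 7.5-fold higher number from compound 1 to compound 4 (0.87 log units; beyond the scatter).

As far as these compounds go, how an amine or a carboxylic acid would fare at this place on the ring remains open. So does how far compound 3 and compound 4 lie past the limit.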